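Thiophene for furan on a weakly active core

The source may hold more compounds than are shown below. What is called first, only, known or untested is meant among the compounds shown, and "the series" means these compounds.

Compound 3 `CC(C)N(Cc1nc(-c2ccco2)no1)C(=O)c1cc2ccccc2o1` carries a furan-2-yl group on its core and was tested in a functional assay on MDA-MB-231 cells (Homo sapiens) for antiproliferative activity, read by sulforhodamine B assay; a higher number here means a weaker inhibitor, a lower number a stronger inhibitor. In this assay compound 3 gives only a limit, > 40000 nM, rather than a number. Its companions show where the set sits: compound 1 `CCCc1ccc(OCC(=O)N(Cc2nc(-c3ccc4ccccc4n3)no2)C(C)C)cc1` gives 35000 nM in this assay, and compound 2 `CCCc1ccc(OCC(=O)N(Cc2nc(-c3cccs3)no2)C(C)C)cc1` gives 27000 nM. The step of a 1.3-fold lower number from compound 1 to compound 2 (0.11 log units; within the scatter) is the only one measured in this set, and it concerns a different exchange, a quinolin-2-yl group replaced by thiophen-2-yl, on a core that also differs from that of compound 3. Compound 4 `CC(C)N(Cc1nc(-c2cccs2)no1)C(=O)c1cc2ccccc2o1` arises from compound 3 by thiophen-2-yl in place of furan-2-yl on an aromatic carbon. Among the measured compounds shown here, no measured pair shows furan-2-yl against thiophen-2-yl, so the closest guide is that thiophen-2-yl in compound 2 left the number near that of compound 1. Compound 3 itself stands at the limit (the limit of > 40000 nM in this assay, at which 1 of the 3 values shown sits). For compound 4 in this assay the step of a number no higher from compound 3 to compound 4 (the limit leaves the size open) is expected to remain within the scatter. Compound 4 is therefore estimated at 40000 nM, with a range from 20000 nM to 80000 nM, and it may well again be reported only as a limit.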

Compound 4, half-maximal inhibitory concentration: > 40000 nM
Compound 4 was reported as a limit; the forecaster's own chance of this, stated with the estimate: 55%; the middle value lies on the limit itself.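

In this assay compound 4 is reported only as a limit, > 40000 nM. Compound 3 is also reported only as a limit, so no step can be read between compound 3 and compound 4: the limit of > 40000 nM in this assay, at which 2 of the 4 values shown sit. The compounds shown leave open whether thiophen-2-yl in place of furan-2-yl changes the number at all.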